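The source may report more compounds than this note shows. Statements on the series, on what has been measured and on what is new or still open speak of the compounds shown alone.

Three small acids built on one shared core have been tested in an assay on isolated protein for inhibition of 2-Hydroxyacid oxidase 2 (Rattus norvegicus), tested at 1 uM; on this read-out higher numbers stand for a stronger effect at the one concentration tested and lower numbers for a weaker effect. Compound 1 `Cc1n[nH]c(C(=O)O)c1Cc1cccc(C(=O)O)c1` gives 7%, compound 2 `Cc1n[nH]c(C(=O)O)c1Cc1ccccc1Oc1ccccc1` gives 10%, and compound 3 `Cc1c(Cc2cccc(-c3ccc(F)cc3)c2)c(C(=O)O)nn1C` gives 12%. Compound 2 sits within the scatter of both neighbours, so none of the three can be told apart on these numbers.

Compound 4 `Cc1n[nH]c(C(=O)O)c1Cc1ccccc1-c1ccc(F)cc1` has not yet been measured. It differs from compound 2 in one place: 4-fluorophenyl in place of phenoxy on an aromatic carbon. Compound 3 already carries the same 4-fluorophenyl group and reads 12%, which is no stronger than compound 2.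

The expected step in this assay from compound 2 to compound 4 is therefore a number 2 percentage points higher from compound 2 to compound 4 (within the scatter), nothing beyond the scatter. Compound 4 is estimated to give 12%, between 0% and 28%.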

Compound 4, a percentage reported as inhibition, at one concentration (the size of the read-out at that concentration, not a potency): 21%
The estimate for compound 4 lay 9 percentage points below the measured number, and the stated range covers the measured number.
By their numbers in this assay, from the lowest: compounds 1, 2, 3 and 4 (each within the scatter of the next, the first and the last beyond it).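

In this assay, 4-fluorophenyl in place of phenoxy on this aromatic carbon, ortho to a large group, gives a number 11 percentage points higher from compound 2 to compound 4 (beyond the scatter). The read-out at this position therefore depends on which group it carries, even though both groups have the same heavy-atom count and one aromatic ring of carbon only. No measurement shown explains the step. Open, on these data alone, is whether the fluorine matters to the step, which a plain phenyl on this carbon would help settle. Also open, as far as these compounds go, is how an amine at this place would read.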